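The source may hold more compounds than are shown below. What is called first, only, known or untested is meant among the compounds shown, and "the series" means these compounds.

Measured compounds in a toxicity assay on MCF-10A cells (Homo sapiens) for inhibition, read by MTT assay, with a stated time of 72 h; on this read-out lower numbers stand for stronger inhibition of growth and higher numbers for weaker inhibition of growth:
Compound 1 `COc1ccc(CNCCCNS(=O)(=O)c2cc(C(F)(F)F)cc(C(F)(F)F)c2)cc1OC` gives 5300 nM.
Compound 2 `O=S(=O)(NCCCNCc1ccccc1)c1cc(C(F)(F)F)cc(C(F)(F)F)c1` gives 13000 nM.
Compound 3 `COc1ccc(CNCCCNS(=O)(=O)c2cc(C(F)(F)F)cc(C(F)(F)F)c2)cc1` gives 3100 nM.

Compound 3 has the lowest of the three numbers in this assay. The steps of a 1.7-fold lower number from compound 1 to compound 3 (0.23 log units; within the scatter) and a 4.2-fold lower number from compound 2 to compound 3 (0.62 log units; beyond the scatter) both end at compound 3; the first lies within the scatter, the second beyond it, so compound 3 is set apart from compound 2 but not from compound 1.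

Compound 4 `COc1cccc(CNCCCNS(=O)(=O)c2cc(C(F)(F)F)cc(C(F)(F)F)c2)c1` has not been measured. It differs from compound 3 by 3-methoxyphenyl in place of 4-methoxyphenyl on a saturated chain carbon bound to an amine nitrogen. For the measured compounds named here, no measured pair moves a methoxy from one aromatic carbon to another, so the only guides are the methoxy changes already seen, a 1.7-fold lower number from compound 1 to compound 3 (0.23 log units; within the scatter) and a 4.2-fold lower number from compound 2 to compound 3 (0.62 log units; beyond the scatter), both of modest size. Removing a methoxy or adding one shifted the numbers only a little, and relocating one is expected to do no more. The step of a 1.4-fold higher number from compound 3 to compound 4 (0.13 log units; within the scatter) is therefore expected to be small, most likely toward a somewhat higher number, and it may well fall within the scatter. Compound 4 is estimated at 4200 nM, with a range of 1600 nM to 11000 nM.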

Compound 4, concentration for 50% growth inhibition: 6600 nM
Estimate against measurement, compound 4: 1.6-fold (0.20 log units) below, within the range that was stated.
By their numbers in this assay, from the lowest: compounds 3, 1, 4 and 2 (each within the scatter of the next, the first and the last beyond it).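

In this assay, for the compounds shown here, the move of the methoxy shows what the earlier compounds could not, that its place on the ring counts and not only its presence, with a 2.1-fold higher number from compound 3 to compound 4 (0.33 log units; beyond the scatter) when 3-methoxyphenyl enters for 4-methoxyphenyl on a saturated chain carbon bound to an amine nitrogen. The 3-methoxyphenyl on its own brings a 2.0-fold lower number from compound 2 to compound 4 (0.29 log units; within the scatter), and the same methoxy change reads differently depending on what else the ring carries: the same change on two cores in this assay, a 1.7-fold lower number (0.23 log units; within the scatter) from compound 1 to compound 3 and a 2.0-fold higher number (0.29 log units; within the scatter) from compound 4 to compound 2, 3.4-fold (0.53 log units) apart, beyond the scatter of two such steps. Taking away the methoxy that the 3-methoxyphenyl lacks gives a 1.2-fold higher number from compound 1 to compound 4 (0.10 log units; within the scatter), so the methoxy that set the 4-methoxyphenyl apart on the plain phenyl does little once a second methoxy is present: the same change on two cores in this assay, a 4.2-fold lower number (0.62 log units; beyond the scatter) from compound 2 to compound 3 and a 1.2-fold lower number (0.10 log units; within the scatter) from compound 4 to compound 1, 3.4-fold (0.53 log units) apart, beyond the scatter of two such steps.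

Open, as far as these compounds go, is whether a hydroxy group, a chlorine or an amine in place of the methoxy would follow the same pattern, and whether a longer chain would keep these differences. From the compounds shown here alone, all of this rests on this assay alone, so how the same steps would read in other cells also stays open.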